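Iodo in place of phenyl: working notes on the series

This account rests on a few compounds, and the source may have more. Where it says the series, first, only, none or still open, it means among the compounds named here.

In a functional assay on MCF7 cells (Homo sapiens) for inhibition, read by sulforhodamine B assay, with a stated time of 48 h (a higher number here means a weaker inhibitor of growth, a lower number a stronger inhibitor of growth), compound 1 `c1cc2c(cc1NC1=NCCO1)CCC2` gives 9100 nM and compound 2 `c1ccc(-c2ccc(NC3=NCCO3)cc2)cc1` gives 10600 nM as a pair within the scatter of each other. Compound 3 `c1ccc(Oc2ccc(NC3=NCCO3)cc2)cc1` gives 3500 nM and lies beyond the scatter from compound 2, with a lower number. Compound 2 thus stands level with compound 1 and above compound 3.

Compound 4 `Ic1ccc(NC2=NCCO2)cc1` carries iodo in place of phenyl on an aromatic carbon and has no measured value yet. Going by the values given here, no measured pair shows this change, so no step beyond the scatter is expected in this assay, in either direction. The estimated step of a 1.2-fold lower number from compound 2 to compound 4 (0.07 log units; within the scatter) is small. Compound 4 is estimated at 9000 nM with an expected range from 3000 nM to 27000 nM for repeat measurements.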

Compound 4, concentration for 50% growth inhibition: 2900 nM
For compound 4 the middle estimate is 3.1-fold (0.49 log units) above the measured one; the whole stated range lies above it.
By their numbers in this assay, from the lowest: compounds 4 and 3 (each within the scatter of the next); then compounds 1 and 2 (each within the scatter of the next).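

At this position the phenyl ring is not needed for growth inhibition: in this assay iodo in place of phenyl on an aromatic carbon gives a 3.7-fold lower number from compound 2 to compound 4 (0.56 log units; beyond the scatter) and so a modest gain beyond the scatter. The smaller group therefore does better here than the phenyl of the earlier compound 2, and the aromatic ring that leaves is dispensable in this series. Nothing on hand accounts for this step.

On these data alone, whether chloro, an amine or a carboxylic acid at this carbon would keep the lower number remains open. Also open, as far as these compounds go, is whether the same change would give a similar step on the core of compound 1.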